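Swapping Trifluoromethyl for Methoxy on a Carbonyl Carbon

The source may report more compounds than this note shows. Statements on the series, on what has been measured and on what is new or still open speak of the compounds shown alone.

Among the compounds with values here, in a functional assay on MCF7 cells (Homo sapiens) for inhibition (a higher number here means a weaker inhibitor, a lower number a stronger inhibitor), compound 1 `CCCCCCCC[C@@]1(C)SC(O)=CC1=O` gives 12.6 ug/mL and compound 2 `CCCCCCCC[C@@]1(C)SC(O)=C(C(=O)C(F)(F)F)C1=O` gives 14.7 ug/mL as the only two numbers so far. Compound 2 therefore stands level with compound 1 within the scatter of repeated measurements. Within the data shown here, the one measured step, a 1.2-fold higher number from compound 1 to compound 2 (0.07 log units; within the scatter) when (trifluoromethyl)carbonyl takes the place of hydrogen on a double-bonded ring carbon, is too small to count as a real change.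

Compound 3 `CCCCCCCC[C@@]1(C)SC(O)=C(C(=O)OC)C1=O` has not yet been measured. It differs from compound 2 by methoxy in place of trifluoromethyl on a carbonyl carbon, so (trifluoromethyl)carbonyl becomes methoxycarbonyl. Among the measured compounds shown here, no measured step tests this swap directly, which makes any forecast a cautious one. The best available guide is compound 2, whose value of 14.7 ug/mL stays within the scatter of compound 1 even with the whole group added, so no step beyond the scatter is expected in this assay for this swap. The estimated step is a 1.1-fold lower number from compound 2 to compound 3 (0.05 log units; within the scatter) and would therefore be a small one. For compound 3 the estimated value is 13 ug/mL with an expected range of 6 ug/mL to 28 ug/mL around it.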

Compound 3, half-maximal inhibitory concentration: 18.7 ug/mL
For compound 3 the middle estimate is 1.4-fold (0.16 log units) below the measured one; low and high end bracket the measured number.
By their numbers in this assay, from the lowest: compounds 1, 2 and 3 (each within the scatter of the next).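

In this assay, putting methoxy in place of trifluoromethyl on a carbonyl carbon gives a 1.3-fold higher number from compound 2 to compound 3 (0.10 log units; within the scatter), so two quite different groups on this carbonyl carbon cannot be told apart by this read-out. Compared with the plain hydrogen of compound 1, methoxycarbonyl on the double-bonded ring carbon gives a 1.5-fold higher number from compound 1 to compound 3 (0.17 log units; within the scatter), which means that a second carbonyl-containing group, and not only (trifluoromethyl)carbonyl, leaves the number level with compound 1. All three compounds therefore stand level here, and no measurement at hand offers an explanation for this.

The compounds shown leave open whether any group at this place can move the number beyond the scatter, in either direction, since only hydrogen and two carbonyl-containing groups appear there. A carboxylic acid, an amide or a carbonyl group carrying a longer chain or an amine would test this further, and a clear step from any of them would show whether this place matters for inhibition at all.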